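A Third Methoxy on the Ring Beside the Carbonyl

This account rests on a few compounds, and the source may have more. Where it says the series, first, only, none or still open, it means among the compounds named here.

Compound 1, `COc1cc(-c2cc(/C=C/C(=O)c3ccc(N)cc3)[nH]n2)cc(OC)c1OC`, gives 34000 nM in a functional assay on SNB-19 cells (Homo sapiens) for inhibition, read by sulforhodamine B assay, with a stated time of 48 h; on this read-out lower numbers stand for higher toxicity in this test and higher numbers for lower toxicity in this test. Compound 2, `COc1cc(-c2cc(/C=C/C(=O)c3ccc(Cl)c(Cl)c3)[nH]n2)cc(OC)c1OC`, reaches only the limit of this assay, > 100000 nM. Compound 3, `COc1ccc(C(=O)/C=C/c2cc(-c3cc(OC)c(OC)c(OC)c3)n[nH]2)cc1OC`, gives 6360 nM in this assay.

Of the two plain numbers, compound 3 holds the lower one, and the gap to its nearest neighbour is a 5.3-fold lower number from compound 1 to compound 3 (0.73 log units; beyond the scatter). For compound 2 the assay gave only a limit, (the limit of > 100000 nM in this assay, at which 1 of the 3 values shown sits).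

Compound 4, `COc1cc(C(=O)/C=C/c2cc(-c3cc(OC)c(OC)c(OC)c3)n[nH]2)cc(OC)c1OC`, differs from compound 3 by methoxy in place of hydrogen on an aromatic carbon. All three measured steps change the same ring, the one attached to the carbonyl carbon: an at least 2.9-fold higher number from compound 1 to compound 2 (0.46 log units; beyond the scatter), a 5.3-fold lower number from compound 1 to compound 3 (0.73 log units; beyond the scatter) and an at least 15-fold lower number from compound 2 to compound 3 (1.19 log units; beyond the scatter). In both steps that put methoxy groups on this ring the number fell. Going by the values given here, none of them, however, adds a single methoxy to a ring that already carries two, so the present change has no direct precedent among the measured compounds.

The step is therefore expected to be small, likely within the scatter or a modest further fall: a 1.3-fold lower number from compound 3 to compound 4 (0.10 log units; within the scatter). Compound 4 is thus estimated at 5000 nM in this assay, with a plausible range from 1800 nM to 14000 nM.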

Compound 4, concentration lethal to 50% of the cells: 8200 nM
Estimate against measurement, compound 4: 1.6-fold (0.21 log units) below, and the stated range covers the measured number.
By their numbers in this assay, from the lowest: compounds 3 and 4 (each within the scatter of the next); then compound 1. At a limit, above all of these: compound 2.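

Adding a third methoxy group to the ring attached to the carbonyl gives a 1.3-fold higher number from compound 3 to compound 4 (0.11 log units; within the scatter) in this assay, so a methoxy group at this position, ortho to a methoxy group and meta to a large group, leaves no readable mark on this test. Going by these compounds alone, the earlier steps on this ring all lay beyond the scatter, the largest being an at least 15-fold lower number from compound 2 to compound 3 (1.19 log units; beyond the scatter), and this is the first step there to lie within it: with two methoxy groups already on the ring, one more does not separate the two compounds. Nothing in the data at hand bears on how this result comes about.

On these data alone, whether the same position would stay as undemanding with a different group, such as a hydroxyl, a carboxylic acid or a longer chain like ethoxy, remains open. Also open, as far as these compounds go, is how a ring carrying a single methoxy group would read in this test, which would show whether the first methoxy or the second accounts for the distance from the other compounds.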